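This account rests on a few compounds, and the source may have more. Where it says the series, first, only, none or still open, it means among the compounds named here.

Measured in a functional assay on LNCaP cells (Homo sapiens) for cytotoxicity, read by sulforhodamine B assay, with a stated time of 72 h (on this read-out higher numbers stand for weaker inhibition and lower numbers for stronger inhibition), where each result is a limit and not a number:

Compound 1 `COc1cc(/C=C/C(=O)/C=C(O)/C=C/c2ccc(OC(C)(C)C(=O)Nc3ccc(Cl)c(C(F)(F)F)c3)c(OC)c2)ccc1O`: > 100000 nM.
Compound 2 `COc1ccc(/C=C/C(=O)/C=C(O)/C=C/c2ccc(OC(C)(C)C(=O)Nc3ccc([N+](=O)[O-])c(C(F)(F)F)c3)c(OC)c2)cc1OC`: > 100000 nM.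
Compound 3 `COc1ccc(/C=C/C(=O)/C=C(O)/C=C/c2ccc(OC(C)(C)C(=O)Nc3ccc(C#N)c(C(F)(F)F)c3)c(OC)c2)cc1OC`: > 100000 nM.

Compound 3 has no exact value, only the limit > 100000 nM. The other two results shown are limits as well.

Compound 4 `COc1ccc(/C=C/C(=O)/C=C(O)/C=C/c2ccc(OC(C)(C)C(=O)Nc3ccc(Cl)c(C(F)(F)F)c3)c(OC)c2)cc1OC` differs from compound 3 at one place: chloro in place of cyano on an aromatic carbon. It has chloro in place of cyano on an aromatic carbon, ortho to a trifluoromethyl group.

Within the data shown here, the only measured step bearing on this change is a step that the two limits leave unreadable from compound 2 to compound 3, which also alters the group at this place but gives no size to carry over. Compound 1 already carries the 4-chloro-3-(trifluoromethyl)phenyl group, and its result is again a limit, > 100000 nM.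

Compound 4 is therefore expected to resemble compound 3 at > 100000 nM, because of the limit of > 100000 nM in this assay, at which 3 of the 3 values shown sit. The expected change is a number no higher from compound 3 to compound 4 (the limit leaves the size open), with no shift in either direction beyond the usual scatter. The estimated value for compound 4 is 100000 nM, within an expected range from 40000 nM to 200000 nM.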

Compound 4, half-maximal inhibitory concentration: > 100000 nM
Compound 4: no number, only a limit (the forecaster's own chance of this, stated with the estimate: 85%); the middle value sits exactly at the limit.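

Compound 4 gives a limit and not a number, as do compound 1, compound 2 and compound 3, so no step among these compounds can be read. The compounds shown leave open how strongly any of them acts, and whether swapping these groups changes that at all.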